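Nitro for amino on a fused oxindole core

The source may hold more compounds than are shown below. What is called first, only, known or untested is meant among the compounds shown, and "the series" means these compounds.

Compound 1 `Nc1ccc2c(c1)/C(=C1\C(=O)Nc3ccccc31)C(=O)N2`: 25000 nM
Compound 2 `O=C1Nc2cc([N+](=O)[O-])ccc2/C1=C1/Nc2ccccc2C1=O`: 2000 nM

In a functional assay on NCI/ADR cells (Homo sapiens) for antiproliferative activity, with a stated time of 72 h (on this read-out higher numbers stand for weaker inhibition and lower numbers for stronger inhibition), compound 1 gives the higher of the two numbers; compound 2 gives a value 2000 nM that sits well apart from it. Compound 3 `O=C1Nc2ccccc2/C1=C1\C(=O)Nc2ccc([N+](=O)[O-])cc21` is not yet measured. It differs from compound 1 by nitro in place of amino on an aromatic carbon. For the measured compounds named here, with no directly comparable pair measured, the step is expected to be moderate and toward a lower number, guided only by the lower value of nitro-bearing compound 2 2000 nM. The estimate for compound 3 is 8000 nM, within 1500 nM to 40000 nM, a step of a 3.1-fold lower number from compound 1 to compound 3 (0.49 log units; beyond the scatter).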

Compound 3, half-maximal inhibitory concentration: 25000 nM
Compound 3: middle estimate off by 3.1-fold (0.49 log units), on the low side; the range from low to high includes it.
By their numbers in this assay, from the lowest: compound 2; then compounds 1 and 3 (each within the scatter of the next).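

For the compounds shown here, at this aromatic carbon of the shared core, nitro in place of amino gives no change at the digits printed from compound 1 to compound 3 (within the scatter) in this assay, and this is the first direct comparison of the two groups at this position. The lower value of compound 2 therefore does not carry over to compound 3, which differs from it in more than one place. Nothing measured here offers an explanation for this result. On these data alone, what a carboxylic acid, a nitrile or a methoxy group would do at this carbon remains open, as does whether the same exchange elsewhere on the core would change the value.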